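Ester variation on a glucoside series: cyclohexylethyl to isopentyl

The compounds below may be only part of what the source reports. "The series", "measured", "known", "first", "only" and "open" are said of these compounds alone.

Three compounds of the shared core have numbers in a functional assay on MCF7 cells (Homo sapiens) for antiproliferative activity, read by MTT assay, with a stated time of 72 h; on this read-out lower numbers stand for stronger inhibition and higher numbers for weaker inhibition. Compound 1 `C/C=C1/[C@H](O[C@@H]2O[C@H](COC(C)=O)[C@@H](OC(C)=O)[C@H](OC(C)=O)[C@H]2OC(C)=O)OC=C(C(=O)OC)[C@H]1CC(=O)OCCC` gives 15000 nM. Compound 2 `C/C=C1/[C@H](O[C@@H]2O[C@H](CO)[C@@H](O)[C@H](O)[C@H]2O)OC=C(C(=O)OC)[C@H]1CC(=O)OCCC1CCCCC1` gives 5000 nM. Compound 3 `C/C=C1/[C@H](O[C@@H]2O[C@H](CO)[C@@H](O)[C@H](O)[C@H]2O)OC=C(C(=O)OC)[C@H]1CC(=O)OCCCCCCCCCCCCCCC` gives 2000 nM. Within these three, compound 2 stands second highest: compound 3 sits lower than compound 2 by a gap beyond the scatter, and compound 1 sits higher than compound 2 by a gap also beyond the scatter. Among the measured compounds shown here, no pair among them differs in a single place, so no single-point step is available.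

Compound 4 `C/C=C1/[C@H](O[C@@H]2O[C@H](CO)[C@@H](O)[C@H](O)[C@H]2O)OC=C(C(=O)OC)[C@H]1CC(=O)OCCC(C)C` is not yet measured. It differs from compound 2 as follows: isopropyl in place of cyclohexyl on a saturated chain carbon, two bonds along the chain from an oxygen next to a carbonyl group. Comparison of compound 2 with compound 3 shows a lower number for the compound carrying the longer ester chain; compound 4 carries the smaller of the two groups described in the difference. For compound 4 a modest rise from compound 2, a 1.6-fold higher number from compound 2 to compound 4 (0.20 log units; within the scatter), is therefore expected in this assay, near the edge of the scatter. The estimated value for compound 4 is 8000 nM, with a range from 3500 nM to 20000 nM.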

Compound 4, half-maximal inhibitory concentration: 21300 nM
The estimate for compound 4 lay 2.7-fold (0.43 log units) below the measured number, outside the stated range (above it).
By their numbers in this assay, from the lowest: compound 3; then compound 2; then compounds 1 and 4 (each within the scatter of the next).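

In this assay, among the compounds shown here, isopropyl in place of cyclohexyl on a saturated chain carbon, two bonds along the chain from an oxygen next to a carbonyl group, gives a 4.3-fold higher number from compound 2 to compound 4 (0.63 log units; beyond the scatter) and provides the first single-place step, one that lies beyond the scatter. This position is therefore not indifferent to the group it carries, and here the cyclohexyl compound holds the lower number. No measurement shown explains the step.

Because the change removes the ring and also shortens the group, the two effects remain unseparated; an open n-hexyl chain or a phenyl ring at this position would help to tell them apart. On these data alone, whether the change behaves alike with the sugar hydroxyls acetylated, as in compound 1, also stays open.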